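The source may report more compounds than this note shows. Statements on the series, on what has been measured and on what is new or still open speak of the compounds shown alone.

In an ADME assay on liver (Mesocricetus auratus) for metabolic stability, using microsomes (a lower number here means slower removal, a higher number faster removal of the compound), three compounds sharing one core have been measured. Compound 1 `O=C(Nc1cc(-c2ccccn2)n[nH]1)N1CCC(c2cccc(F)c2)CC1` gives 207 mL.min-1.g-1, compound 2 `N#Cc1ccc(C2CCN(C(=O)Nc3cc(-c4ccccn4)n[nH]3)CC2)cc1` gives 80.8 mL.min-1.g-1, and compound 3 `O=C(Nc1cc(-c2ccccn2)n[nH]1)N1CCC(Oc2ccccc2)CC1` gives 98.5 mL.min-1.g-1. The nearest comparison for the phenoxy compound is a 1.2-fold higher number from compound 2 to compound 3 (0.09 log units; within the scatter), while a 2.1-fold lower number from compound 1 to compound 3 (0.32 log units; beyond the scatter) sets it apart from the highest number of the three.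

Compound 4 `O=C(Nc1cc(-c2ccccn2)n[nH]1)N1CCC(c2ccc(Cl)cc2)CC1` brings a new change, 4-chlorophenyl in place of phenoxy on a saturated ring carbon. The measured steps give mixed guidance, since compound 1 and compound 2 both carry a substituted phenyl at this place, yet they are separated by a 2.6-fold lower number from compound 1 to compound 2 (0.41 log units; beyond the scatter). Compound 1 points to a higher number for compound 4, whereas compound 2 points to no change, so a small rise is expected rather than a step clearly beyond the scatter. The expected change is a 1.6-fold higher number from compound 3 to compound 4 (0.21 log units; within the scatter). For compound 4 the estimated value is 160 mL.min-1.g-1, with an expected range from 80 mL.min-1.g-1 to 300 mL.min-1.g-1.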

Compound 4, intrinsic clearance in microsomes: 43.8 mL.min-1.g-1
Estimate against measurement, compound 4: 3.7-fold (0.56 log units) above; the whole stated range lies above it.
By their numbers in this assay, from the lowest: compounds 4, 2 and 3 (each within the scatter of the next, the first and the last beyond it); then compound 1.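

In this assay, replacing phenoxy with 4-chlorophenyl on the saturated ring carbon keeps the heavy-atom count and removes the hydrogen-bond acceptor, giving a 2.2-fold lower number from compound 3 to compound 4 (0.35 log units; beyond the scatter), so an aryl group joined directly at this place need not carry a higher number than phenoxy. Among these compounds, the choice of aryl group matters more than the earlier compounds showed: a 4.7-fold lower number from compound 1 to compound 4 (0.67 log units; beyond the scatter) is the largest step in the set. By contrast, chloro in place of cyano gives a 1.8-fold lower number from compound 2 to compound 4 (0.27 log units; within the scatter), so 4-chlorophenyl and 4-cyanophenyl cannot be told apart here.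

No measurement shown accounts for these differences. The compounds shown leave open whether the gap from 3-fluorophenyl to 4-chlorophenyl follows the halogen or its place on the phenyl ring, and how an amine or a carboxylic acid on that ring would read in this assay.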